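Swapping the Aryl Group on a Shared Core

The source may hold more compounds than are shown below. What is called first, only, known or untested is meant among the compounds shown, and "the series" means these compounds.

Compound 1, `N#CCCCn1c(Cn2c(=O)n(-c3ccc(C(=O)NC4CC4)cc3)c3ccncc32)cc2cc(Cl)ccc21`: in an ADME assay on HeLa cells (Homo sapiens) for cytotoxicity, read by ATP content, with a stated time of 3 days (a lower number here means that less compound is tolerated, a higher number that more compound is tolerated), compound 1 gives > 50000 nM, a limit of the assay.
Compound 2, `N#CCCCn1c(Cn2c(=O)n(-c3ncco3)c3ccncc32)cc2cc(Cl)ccc21`: in this assay compound 2 gives > 50000 nM, also a limit.
Compound 3, `N#CCCCn1c(Cn2c(=O)n(-c3ccncn3)c3ccncc32)cc2cc(Cl)ccc21`: in this assay compound 3 gives > 50000 nM, again a limit.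

Compound 3 therefore stands only at a limit, with no number of its own. Compound 4, `COc1ccc(-n2c(=O)n(Cc3cc4cc(Cl)ccc4n3CCCC#N)c3cnccc32)cc1C`, differs from compound 3 by 4-methoxy-3-methylphenyl in place of pyrimidin-4-yl on an aromatic nitrogen. The measured steps that touch this position are a step that the two limits leave unreadable from compound 1 to compound 3, a step that the two limits leave unreadable from compound 2 to compound 3 and a step that the two limits leave unreadable from compound 1 to compound 2; all three compounds sit at the limit of > 50000 nM in this assay, at which 3 of the 3 values shown sit, so no size can be read from them. For the measured compounds named here, nothing among the measured compounds points to a change beyond the scatter in this assay. Compound 4 is expected near 60000 nM, in the range 30000 nM to 200000 nM, most likely reported again as a limit. The expected step is a step that the limit leaves unreadable from compound 3 to compound 4.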

Compound 4, half-maximal cytotoxic concentration: > 50000 nM
Compound 4: a limit, no number (the forecaster's own chance of this, stated with the estimate: 85%); the middle value does not contradict the limit.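

The steps from compound 1, compound 2 and compound 3 to compound 4 cannot be read, because all four compounds share one limit: the limit of > 50000 nM in this assay, at which 4 of the 4 values shown sit.

As far as these compounds go, whether any group at this position changes the tolerated concentration in this assay remains open.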